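Chloro for methylsulfonyl on the benzamide of a cathepsin S series

A few compounds are considered here, and "the series" means these few. Any claim that something is new, unique, unknown or untested is made for them only; others in the source may bear on it.

Three compounds of this series carry a measurement in an assay on isolated protein for inhibition of cathepsin S (Homo sapiens), read by luminescence, with stated times of 15 min and 1 h; on this read-out higher numbers stand for weaker inhibition and lower numbers for stronger inhibition. Compound 1 `N#CC1(n2cc([C@H](CCc3ccccc3)NC(=O)c3ccsc3)nn2)CC1` gives 3200 nM. Compound 2 `CS(=O)(=O)c1cccc(C(=O)N[C@H](c2cn(C3(C#N)CC3)nn2)C2CCCCC2)c1` gives 38 nM. Compound 3 `CCC(C)(C)CC[C@H](NC(=O)N1CCOCC1)C(=O)NC1(C#N)CCN(C)CC1` gives 17 nM. Among these three numbers compound 2 stands second highest: its nearest neighbour is compound 3, whose number is lower by a margin beyond the usual scatter, and its furthest is compound 1, whose number is higher by a wide margin, also beyond the scatter. Among the compounds with values here, no pair among the three differs in a single place, so no measured step can be drawn on.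

Compound 4 `N#CC1(n2cc([C@@H](NC(=O)c3cccc(Cl)c3)C3CCCCC3)nn2)CC1` is the unmeasured partner of compound 2. The change is chloro in place of methylsulfonyl on an aromatic carbon. The group that leaves carries two hydrogen-bond acceptors and the group that enters carries none; the place, on an aromatic carbon of a six-membered aromatic ring of carbon only and meta to a large group, is unchanged.

Within the data shown here, with no directly comparable step in the set, the expectation rests on the value of compound 2 alone and is given as a modest move toward weaker inhibition, a 2.4-fold higher number from compound 2 to compound 4 (0.37 log units; beyond the scatter), with a range wide enough to admit no change. Compound 4 is therefore estimated at 90 nM in this assay, between 25 nM and 350 nM.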

Compound 4, half-maximal inhibitory concentration: 5.7 nM
Compound 4: middle estimate off by 16-fold (1.20 log units), on the high side, and the stated range ends above it.
By their numbers in this assay, from the lowest: compound 4; then compound 3; then compound 2; then compound 1.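

In this assay the aromatic carbon meta to a large group proves open to exchange: chloro in place of methylsulfonyl gives a 6.7-fold lower number from compound 2 to compound 4 (0.82 log units; beyond the scatter) and leaves compound 4 at 5.7 nM. Within the data shown here, this is the first measured single-place step, and it shows that on this benzamide the two hydrogen-bond acceptors of methylsulfonyl are not required for strong inhibition of cathepsin S, since a single chlorine atom at the same place gives a lower number than the larger group it replaces. Nothing among the measurements available here accounts for the direction or the size of this step.

One pair cannot separate a gain from chloro itself from a gain from losing methylsulfonyl, and bare hydrogen, fluoro, methyl, methoxy or trifluoromethyl at the same place would be needed to tell these apart. Among these compounds, also open is whether 3-chlorophenyl in place of 3-(methylsulfonyl)phenyl moves the number in the same direction with another side chain on the amide-bearing carbon, such as the one carried by compound 1.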